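A Chloro Group on the Inactive Phenyl Compound

This account rests on a few compounds, and the source may have more. Where it says the series, first, only, none or still open, it means among the compounds named here.

In a functional assay on A549 cells (Homo sapiens) for inhibition, read by sulforhodamine B assay, with a stated time of 74 h (on this read-out lower numbers stand for stronger inhibition and higher numbers for weaker inhibition), compound 2 `O=C1C=CC2(C=C1)OCC(=O)N2S(=O)(=O)c1ccccc1` gives > 10000 nM, which is a limit of the assay and not a number. Compound 1 `Cc1ccc(S(=O)(=O)N2C(=O)COC23C=CC(=O)C=C3)cc1` gives 110 nM. Among the compounds with values here, the only measured step, an at least 90-fold higher number from compound 1 to compound 2 (1.95 log units; beyond the scatter), is hydrogen in place of methyl on an aromatic carbon, and it is large and beyond the scatter.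

Compound 3 `O=C1C=CC2(C=C1)OCC(=O)N2S(=O)(=O)c1ccc(Cl)cc1` has chloro in place of hydrogen on an aromatic carbon, para to a large group, the phenyl to 4-chlorophenyl change: chloro in place of hydrogen on an aromatic carbon. Chloro is not methyl, so the measured step is only a rough guide. Even so, a large step towards lower numbers is expected in this assay because of an at least 90-fold higher number from compound 1 to compound 2 (1.95 log units; beyond the scatter). The expected change is an at least 33-fold lower number from compound 2 to compound 3 (1.52 log units; beyond the scatter). The estimate for compound 3 is 300 nM, with an expected range of 60 nM to 6000 nM.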

Compound 3, half-maximal inhibitory concentration: > 10000 nM
Compound 3 was reported as a limit; the forecaster's own chance of this, stated with the estimate: 15%; at least 33-fold (1.52 log units) between middle value and limit.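

In this assay, chloro in place of methyl on the aromatic carbon para to a large group gives an at least 90-fold higher number from compound 1 to compound 3 (1.95 log units; beyond the scatter), so at this position chloro does not restore what is seen with methyl. Compound 3 gives > 10000 nM, which is a limit of the assay and not a number. The step between compound 2 and compound 3 cannot be read, and chloro may or may not change anything relative to hydrogen, as both compounds end at the same limit: the limit of > 10000 nM in this assay, at which 2 of the 3 values shown sit.

Among these compounds, only compound 1, the one with methyl, has a measured number. As far as these compounds go, whether methyl itself is needed remains open, and a group such as ethyl, methoxy or an amine at this position would help to show whether the low number of compound 1 is specific to methyl.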